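Aryl ether variation on a shared core and an expected value

The source may report more compounds than this note shows. Statements on the series, on what has been measured and on what is new or still open speak of the compounds shown alone.

Measured compounds:
- compound 1, `Cc1nn(-c2ncnc3nc[nH]c23)c2c1C(OCc1ccc(C#N)cc1)CC(=O)N2`, gives 4 nM
- compound 2, `Cc1nn(-c2ncnc3nc[nH]c23)c2c1C(OCc1ccc(F)cc1)CC(=O)N2`, gives 1 nM
- compound 3, `Cc1nn(-c2ncnc3nc[nH]c23)c2c1C(OCc1ccccc1Cl)CC(=O)N2`, gives 2 nM

All three share one core and differ only in the aryl group carried on a saturated chain carbon bound to an oxygen on a saturated carbon, and all three were tested in a functional assay on HEK293 cells for agonist activity at G-protein coupled receptor 39 (Homo sapiens), read by scintillation proximity assay and inositol phosphate accumulation, with a stated time of 75 min, in the presence of a further agent that is not named here; on this read-out higher numbers stand for an effect only at larger amounts of compound and lower numbers for an effect already at smaller amounts. Compound 3 stands within the scatter of both neighbours: a 2.0-fold lower number from compound 1 to compound 3 (0.30 log units; within the scatter) and a 2.0-fold higher number from compound 2 to compound 3 (0.30 log units; within the scatter), so no order among compound 1, compound 2 and compound 3 can be read from these numbers. Among the measured compounds shown here, the only step that is beyond the scatter, a 4.0-fold lower number from compound 1 to compound 2 (0.60 log units; beyond the scatter), concerns a change on the aromatic ring and is modest.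

Compound 4, `Cc1nn(-c2ncnc3nc[nH]c23)c2c1C(OCc1cc(F)cc3c1OCOC3)CC(=O)N2`, carries a larger group at the same place: a group of 11 heavy atoms (8 carbon, 2 oxygen, 1 fluorine; one six-membered non-aromatic ring with 2 hetero atoms, one six-membered aromatic ring of carbon only) in place of a group of 7 heavy atoms (6 carbon, 1 chlorine; one six-membered aromatic ring of carbon only), on a saturated chain carbon bound to an oxygen on a saturated carbon. The two steps that bear on this exchange, the steps from compound 1 and from compound 2 to compound 3, both stayed within the scatter, but neither adds a second ring, so the expectation is loose. Compound 4 is expected to give 2.5 nM, with a range from 0.6 nM to 12 nM. The step of a 1.3-fold higher number from compound 3 to compound 4 (0.10 log units; within the scatter) is expected to stay within the scatter.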

Compound 4, half-maximal effective concentration: 1.5 nM
Compound 4: the middle estimate sits 1.7-fold (0.22 log units) above what was measured; measured number inside the range.
By their numbers in this assay, from the lowest: compounds 2, 4, 3 and 1 (each within the scatter of the next, the first and the last beyond it).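

Adding a second ring at this place, on a saturated chain carbon bound to an oxygen on a saturated carbon, does not separate compound 4 from the single-ring compounds closest to it: the exchange gives a 1.3-fold lower number from compound 3 to compound 4 (0.12 log units; within the scatter) and a 1.5-fold higher number from compound 2 to compound 4 (0.18 log units; within the scatter). The exchange from the 4-cyanophenyl group does give a 2.7-fold lower number from compound 1 to compound 4 (0.43 log units; beyond the scatter), so compound 1 stands apart from compound 2 and compound 4, although not from compound 3. Nothing available explains how the position accommodates the group of 11 heavy atoms.

All four groups carry a six-membered aromatic ring of carbon, so the compounds shown leave open what an amine, a carboxylic acid or a longer chain would give here. They also leave open what the fluorine and the non-aromatic ring of compound 4 each contribute.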